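Removing a Benzyl Ester: What to Expect for Compound 3

The compounds below may be only part of what the source reports. "The series", "measured", "known", "first", "only" and "open" are said of these compounds alone.

Compound 1, `COc1ccc(NC(=O)c2ccc(CNc3nccc(-c4cccnc4)n3)cc2)c(N)c1`: > 20000 nM
Compound 2, `Nc1cc(C(=O)OCc2ccccc2)ccc1NC(=O)c1ccc(CNc2nccc(-c3cccnc3)n2)cc1`: > 20000 nM

In an assay for inhibition of histone deacetylase 8 (Homo sapiens), read by fluorescence, with stated times of 15 min and 60 min (on this read-out higher numbers stand for weaker inhibition and lower numbers for stronger inhibition), compound 1 gives no number, only a limit of the assay, > 20000 nM. Compound 2 also gives only a limit in this assay, > 20000 nM. Among the measured compounds shown here, both values sit at the limit of > 20000 nM in this assay, at which 2 of the 2 values shown sit, so the one measured step, a step that the two limits leave unreadable from compound 1 to compound 2, has no readable size or direction. Compound 2 therefore stands at the edge of what this assay can report, with nothing beyond.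

Compound 3, `Nc1cc(C(=O)O)ccc1NC(=O)c1ccc(CNc2nccc(-c3cccnc3)n2)cc1`, has not yet been measured. It differs from compound 2 by hydrogen in place of benzyl on an oxygen next to a carbonyl group; cut one bond further out, the same difference reads benzyloxycarbonyl to carboxy.

For the measured compounds named here, no measured step bears on this change with a readable size, so the expectation rests only on where compound 2 stands. The step of a number no higher from compound 2 to compound 3 (the limit leaves the size open) is expected to stay within the scatter. Compound 3 is estimated at 20000 nM in this assay, between 5000 nM and 80000 nM, and will likely again be reported only as a limit.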

Compound 3, half-maximal inhibitory concentration: > 20000 nM
Compound 3 ended at the assay's limit; the forecaster's own chance of this, stated with the estimate: 70%; the middle value lies on the limit itself.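

No step among compound 1, compound 2 and compound 3 can be read in this assay, since all three give only a limit of the assay and no number: the limit of > 20000 nM in this assay, at which 3 of the 3 values shown sit.

The compounds shown leave open how strongly each one inhibits, and whether benzyloxycarbonyl to carboxy changes inhibition at all.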